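Replacing a hydroxypiperidine sulfonamide with a pyrrolidinylpiperidine

This account rests on a few compounds, and the source may have more. Where it says the series, first, only, none or still open, it means among the compounds named here.

The series shares a core in which a benzylurea carries a sulfonyl group on its aromatic ring. Compound 1 `O=C(NCc1ccc(S(=O)(=O)c2cncc(C(F)(F)F)c2)cc1)N1Cc2ccncc2C1` bears a 5-(trifluoromethyl)pyridin-3-yl on the sulfonyl sulfur, and in an assay on isolated protein for inhibition of Nicotinamide phosphoribosyltransferase (Homo sapiens), read by mass spectrometry, with stated times of 15 min and 30 min (on this read-out higher numbers stand for weaker inhibition and lower numbers for stronger inhibition), compound 1 gives 15 nM. Compound 2 `O=C(NCc1ccc(S(=O)(=O)N2CCC[C@H](O)C2)cc1)N1Cc2ccncc2C1` carries 3-hydroxypiperidin-1-yl instead, and in this assay compound 2 gives 770 nM, the highest of the two numbers recorded; the step of a 51-fold higher number from compound 1 to compound 2 (1.71 log units; beyond the scatter) separates it from compound 1.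

Compound 3 `O=C(NCc1ccc(S(=O)(=O)N2CCC(N3CCCC3)CC2)cc1)N1Cc2ccncc2C1` is the next step: 4-(pyrrolidin-1-yl)piperidin-1-yl in place of 3-hydroxypiperidin-1-yl on a sulfonyl sulfur. Among the compounds with values here, only one measured step exists, and it swaps an aromatic group for an amine rather than one amine for another, so it bears on this change only indirectly, showing that the sulfonamide series sits at weaker inhibition than compound 1. Within the data shown here, no measured pair tells how two different cyclic amines on the sulfonyl sulfur compare. Compound 3 is therefore expected to stay near compound 2, with a 1.1-fold lower number from compound 2 to compound 3 (0.04 log units; within the scatter) as the estimated step in this assay, not beyond the scatter in either direction. In this assay compound 3 is estimated at 700 nM, within a range from 150 nM to 3000 nM.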

Compound 3, half-maximal inhibitory concentration: 7.4 nM
The estimate for compound 3 lay 95-fold (1.98 log units) above the measured number, outside the stated range (below it).
By their numbers in this assay, from the lowest: compound 3; then compound 1; then compound 2.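

In this assay, putting 4-(pyrrolidin-1-yl)piperidin-1-yl in place of 3-hydroxypiperidin-1-yl on the sulfonyl sulfur gives a 100-fold lower number from compound 2 to compound 3 (2.02 log units; beyond the scatter), so the choice of cyclic amine at this position can shift the number by a large margin, which the earlier pair, an aromatic group against an amine, could not show. The other comparison, a 2.0-fold lower number from compound 1 to compound 3 (0.31 log units; beyond the scatter), is modest but beyond the scatter, and it shows that an aromatic group on the sulfonyl sulfur is not needed for a low number, since the amine-bearing compound 3 is the strongest inhibitor of the three. No measurement shown here accounts for either step.

The change alters several things at once: the hydroxyl group and the defined stereocentre leave, while a pyrrolidine ring and a second nitrogen enter, and these compounds do not separate their contributions. An unsubstituted piperidin-1-yl would help to show what the hydroxyl group contributes, and 4-(morpholin-4-yl)piperidin-1-yl or 4-(dimethylamino)piperidin-1-yl would test whether the pyrrolidine ring itself matters.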